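The source may hold more compounds than are shown below. What is called first, only, known or untested is meant among the compounds shown, and "the series" means these compounds.

Measured compounds and their values:
Compound 1 `CC1=C(O)/C(=C/[C@H](C)CC/C=C(/C)CC/C=C(/C)CCCC2=CC(O)OC2=O)OC1=O` — in a functional assay on K562 cells (Homo sapiens) for cytotoxicity, read by MTT assay (on this read-out lower numbers stand for higher toxicity in this test and higher numbers for lower toxicity in this test), compound 1 reaches the limit > 100 ug/mL, which is a limit of the assay and not a number.
Compound 2 `COC1C=C(CCC/C(C)=C\CC/C(C)=C\CC[C@@H](C)/C=C2\OC(=O)C(C)=C2O)C(OC)O1` — in this assay compound 2 gives 83 ug/mL.
Compound 3 `COC1C=C(CC/C=C(\C)CC/C=C(\C)CCC[C@@H](C)/C=C2\OC(=O)C(C)=C2O)C(OC)O1` — in this assay compound 3 gives 80 ug/mL.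

Compound 2 and compound 3 are built from the same atoms joined differently; the difference between the two cores is not broken down here, and their two values lie within the scatter of each other. For the measured compounds named here, the one measured step is a group of 7 heavy atoms (4 carbon, 3 oxygen; one five-membered non-aromatic ring with 1 hetero atom) in place of a group of 9 heavy atoms (6 carbon, 3 oxygen; one five-membered non-aromatic ring with 1 hetero atom), on a saturated chain carbon, three bonds along the chain from a double-bonded chain carbon, which gave an at least 1.2-fold higher number from compound 2 to compound 1 (0.08 log units; that floor lies within the scatter). The size of that step is bounded only from below, because of the limit of > 100 ug/mL in this assay, at which 1 of the 3 values shown sits.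

Compound 4 `CC1=C(O)/C(=C/[C@H](C)CCC/C(C)=C/CC/C(C)=C/CCC2=CC(O)OC2=O)OC1=O` is not yet measured. It arises from compound 3 through (a group of 7 heavy atoms (4 carbon, 3 oxygen; one five-membered non-aromatic ring with 1 hetero atom) in place of a group of 9 heavy atoms (6 carbon, 3 oxygen; one five-membered non-aromatic ring with 1 hetero atom), on a saturated chain carbon, two bonds along the chain from a double-bonded chain carbon). Going by the values given here, this is the same kind of change as the one from compound 2 to compound 1, not the same: there the group sits on a saturated chain carbon three bonds along the chain from a double-bonded chain carbon, here two bonds along the chain from a double-bonded chain carbon. Resting on compound 3 with 80 ug/mL and on the measured step of an at least 1.2-fold higher number from compound 2 to compound 1 (0.08 log units; that floor lies within the scatter), compound 4 is expected to show a 1.4-fold higher number from compound 3 to compound 4 (0.14 log units; within the scatter). The estimate for compound 4 in this assay is 110 ug/mL, between 65 ug/mL and 190 ug/mL, and a limit rather than a number is thought the likelier outcome.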

Compound 4, concentration lethal to 50% of the cells: > 100 ug/mL
Compound 4 ended at the assay's limit (the forecaster's own chance of this, stated with the estimate: 60%); the middle value lies beyond the limit too.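

In this assay, the new step is an at least 1.2-fold higher number from compound 3 to compound 4 (0.09 log units; that floor lies within the scatter), with the group of 7 heavy atoms in place of the group of 9 heavy atoms on a saturated chain carbon, two bonds along the chain from a double-bonded chain carbon. Set beside the earlier case, the same exchange on the second core again ends at a limit rather than a number, so the two cores give the same kind of result without either step having a measured size: the same change on two cores in this assay, an at least 1.2-fold higher number (0.08 log units; that floor lies within the scatter) from compound 2 to compound 1 and an at least 1.2-fold higher number (0.09 log units; that floor lies within the scatter) from compound 3 to compound 4; the limit leaves it open whether they differ. This does not show that the change raises the number on either core or that it acts equally on both, because each step is known only as a floor that lies within the scatter: the limit of > 100 ug/mL in this assay, at which 2 of the 4 values shown sit.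

The compounds shown leave open how far the number would move on either core if the end group on the chain were a carboxylic acid or an amine instead of either of these two rings. They also leave open whether a longer chain between that end group and the nearest double-bonded chain carbon would change the outcome in this assay.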